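Chain Extension on the Aryl Ether of a Shared Core

A few compounds are considered here, and "the series" means these few. Any claim that something is new, unique, unknown or untested is made for them only; others in the source may bear on it.

Compound 1 `CCOc1ccc(-c2ncnn2-c2cc(OC)c(OC)c(OC)c2)cc1`, compound 2 `COc1cc(-n2ncnc2-c2ccc(OC(C)C)cc2)cc(OC)c1OC`, compound 3 `COc1ccccc1-c1ncnn1-c1cc(OC)c(OC)c(OC)c1` and the not yet measured compound 4 `CCOc1ccccc1-c1ncnn1-c1cc(OC)c(OC)c(OC)c1` are compared; the difference between the cores of compound 1 and compound 3 is not broken down here. In a functional assay on MCF7 cells (Homo sapiens) for antiproliferative activity, read by MTT assay, with a stated time of 72 h (on this read-out lower numbers stand for stronger inhibition and higher numbers for weaker inhibition), compound 1 gives 50 nM, while compound 2 gives 610 nM. The change methyl in place of hydrogen on a saturated chain carbon bound to an oxygen on an aromatic ring and a saturated chain carbon thus brought a 12-fold higher number from compound 1 to compound 2 (1.09 log units; beyond the scatter). For compound 3 this assay reports only a limit, > 10000 nM, which sits at the limit of > 10000 nM in this assay, at which 1 of the 3 values shown sits. Compound 4 arises from compound 3 by methyl in place of hydrogen on a saturated chain carbon bound to an oxygen on an aromatic ring, the same kind of change, though here the place is simply on a saturated chain carbon bound to an oxygen on an aromatic ring. The expected step that the limit leaves unreadable from compound 3 to compound 4 rests on compound 3 standing at a limit and on the weakening seen in a 12-fold higher number from compound 1 to compound 2 (1.09 log units; beyond the scatter). Compound 4 is therefore estimated at 20000 nM, between 6000 nM and 80000 nM, in this assay.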

Compound 4, half-maximal inhibitory concentration: > 10000 nM
Compound 4 ended at the assay's limit; the forecaster's own chance of this, stated with the estimate: 75%; the middle value lies beyond the limit too.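

In this assay, going by these compounds alone, compound 3 and compound 4 both stand at a limit, so no step between them can be read: the limit of > 10000 nM in this assay, at which 2 of the 4 values shown sit. The compounds shown leave open whether methoxy to ethoxy changes activity at all on the core of compound 3.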